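A Piperazine Ring Returns in Compound 4

A few compounds are considered here, and "the series" means these few. Any claim that something is new, unique, unknown or untested is made for them only; others in the source may bear on it.

Three measured compounds share one core. Compound 1 `COc1ccc(S(=O)(=O)N(C)CCOCC(=O)N(C)Cc2ccc(C3=NCCN3)cc2)c(C)c1`, compound 2 `COc1cc(C)c(S(=O)(=O)N(C)CCOCC(=O)N2CCC(N3CCN(C(C)C)CC3)CC2)c(C)c1` and compound 3 `COc1cc(C)c(S(=O)(=O)N(C)CCOCC(=O)N2CCC(C(O)CN(C)C)CC2)c(C)c1` were all tested in a functional assay on Umbilical vein for antagonist activity at B1 bradykinin receptor (Homo sapiens), using Schild analysis, with a stated time of 30 min (a higher number here means a more potent compound, by a factor of ten per unit of this negative logarithm, a lower number a less potent compound), where compound 1 gives 8.6, compound 2 gives 8.5 and compound 3 gives 7.4. Compound 3 stands lowest of the three: compound 2 is nearest to it and compound 1 furthest, and both gaps lie beyond the scatter. The only single-point step among these compounds is the one from compound 2 to compound 3, where a number 1.10 log units lower from compound 2 to compound 3 (beyond the scatter), a large loss that came with the 2-(dimethylamino)-1-hydroxyethyl group taking the place of 4-isopropylpiperazin-1-yl.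

Compound 4 `COc1cc(C)c(S(=O)(=O)N(C)CCOCC(=O)N2CCC(CN3CCN(C)CC3)CC2)c(C)c1` is not yet measured. It differs from compound 3 by (4-methylpiperazin-1-yl)methyl in place of 2-(dimethylamino)-1-hydroxyethyl on a saturated ring carbon. Among the compounds with values here, this change brings back a six-membered ring with two nitrogens, resembling the group of compound 2, though joined through a methyl link and carrying methyl instead of isopropyl; no measured pair covers that exact difference. Because the loss recorded as a number 1.10 log units lower from compound 2 to compound 3 (beyond the scatter) was large when such a ring left, most of it is expected to return, giving an expected rise of a number 0.80 log units higher from compound 3 to compound 4 (beyond the scatter). Compound 4 is therefore estimated at 8.2, with a range from 7.5 to 8.9.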

Compound 4, negative logarithm of the antagonist equilibrium constant: 8.1
The estimate for compound 4 lay 0.10 log units above the measured number; measured number inside the range.
By their numbers in this assay, from the lowest: compound 3; then compound 4; then compounds 2 and 1 (each within the scatter of the next).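

In this assay there is a number 0.70 log units higher from compound 3 to compound 4 (beyond the scatter) when the open 2-(dimethylamino)-1-hydroxyethyl chain gives way to (4-methylpiperazin-1-yl)methyl, so this saturated ring carbon can carry a piperazine ring joined through a methyl link and a higher number is reached without the hydroxyl group of compound 3. The recovery stops short of the earlier level, with a number 0.40 log units lower from compound 2 to compound 4 (beyond the scatter) and that gap still beyond the usual scatter, so (4-methylpiperazin-1-yl)methyl does not fully stand in for 4-isopropylpiperazin-1-yl at this carbon. That second step changes two things at once, the methyl link and the methyl in place of isopropyl on the far ring nitrogen, and its size cannot be divided between them.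

The compounds shown leave open how a (4-isopropylpiperazin-1-yl)methyl group or a directly attached 4-methylpiperazin-1-yl group would score here, and either one would separate the effect of the link from that of the end group. Nothing shown here offers any explanation for these shifts.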